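Cytotoxicity notes: from 4-ethylphenyl to 2,6-dimethylphenyl

The source may hold more compounds than are shown below. What is called first, only, known or untested is meant among the compounds shown, and "the series" means these compounds.

- Compound 1 `COC1=C(C)C(=O)/C(=C(O)/C=C/c2ccc(Br)cc2)C(=O)C1(C)C`: 1.7 ug/mL
- Compound 2 `CCc1ccc(/C=C/C(O)=C2/C(=O)C(C)=C(OC)C(C)(C)C2=O)cc1`: 6.9 ug/mL

Both values come from a functional assay on KB cells (Homo sapiens) for cytotoxicity; on this read-out higher numbers stand for an effect only at larger amounts of compound and lower numbers for an effect already at smaller amounts. Compound 2 carries the higher of the two numbers, so its effect appears only at the larger amount. The next change leads to compound 3 `COC1=C(C)C(=O)/C(=C(O)/C=C/c2c(C)cccc2C)C(=O)C1(C)C`: 2,6-dimethylphenyl in place of 4-ethylphenyl on a double-bonded chain carbon bound to a double-bonded chain carbon. Among the compounds with values here, one measured step bears on it: a 4.1-fold higher number from compound 1 to compound 2 (0.61 log units; beyond the scatter). This modest step places ethyl where bromo stood on an aromatic carbon, so it shows that a change on the aromatic ring can register in this assay. Within the data shown here, no measured compound carries 2,6-dimethylphenyl, however, and the direction of that step cannot simply be carried over. A number near the upper part of the measured span is therefore expected, with only a slight shift toward lower numbers. The expected step is a 1.4-fold lower number from compound 2 to compound 3 (0.14 log units; within the scatter), not beyond the scatter. For compound 3 the estimated value is 5 ug/mL, with an expected range of 1.5 ug/mL to 16 ug/mL.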

Compound 3, concentration for half-maximal effect: 7.1 ug/mL
Estimate against measurement, compound 3: 1.4-fold (0.15 log units) below; the measured number falls inside the stated range.
By their numbers in this assay, from the lowest: compound 1; then compounds 2 and 3 (each within the scatter of the next).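

In this assay, exchanging 4-ethylphenyl for 2,6-dimethylphenyl on a double-bonded chain carbon bound to a double-bonded chain carbon gives a 1.0-fold higher number from compound 2 to compound 3 (0.01 log units; within the scatter) and so does not separate the two groups, despite their different substitution patterns. Within the data shown here, exchanging 4-bromophenyl for 2,6-dimethylphenyl at the same place gives a 4.2-fold higher number from compound 1 to compound 3 (0.62 log units; beyond the scatter) and thus sets compound 1 apart from both compound 2 and compound 3, where the earlier compounds offered only the single comparison with compound 2. No measurement on hand accounts for either step.

On these data alone, it remains open whether the separation of compound 1 belongs to bromo itself or would recur with chloro on the aromatic ring. As far as these compounds go, what an amine or a carboxylic acid on that ring would give at this position also remains open.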